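Swapping the base on a butenolide chain: compound 1 to compound 4

This account rests on a few compounds, and the source may have more. Where it says the series, first, only, none or still open, it means among the compounds named here.

Measured so far:
- compound 1, `O=C1O/C(=C\Cn2c(=O)[nH]c(=O)[nH]c2=O)C(OCc2ccccc2)=C1OCc1ccccc1`: 44800 nM
- compound 2, `O=C1O/C(=C\Cn2ccc(NC(=O)c3ccccc3)nc2=O)C(OCc2ccccc2)=C1OCc1ccccc1`: 1980 nM
- compound 3, `Nc1ncn(CCC2(N)OC(=O)C(OCc3ccccc3)=C2OCc2ccccc2)c(=O)n1`: a limit, > 100000 nM

In a functional assay on HepG2 cells (Homo sapiens) for inhibition, read by MTT assay, with a stated time of 72 h (a lower number here means a stronger inhibitor, a higher number a weaker inhibitor), compound 1 gives 44800 nM. Within the data shown here, of the two numbers known, that of compound 1 is the higher; compound 2 gives 1980 nM, a lower number that lies beyond the usual scatter, so compound 2 is the stronger inhibitor of the pair. For compound 3 this assay gives only a limit, > 100000 nM, which is not a number; this is the case noted in the limit of > 100000 nM in this assay, at which 1 of the 3 values shown sits.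

Compound 4, `O=C1O/C(=C\Cn2ncc(=O)[nH]c2=O)C(OCc2ccccc2)=C1OCc1ccccc1`, has not been measured. It differs from compound 1 in one place: a group of 8 heavy atoms (3 carbon, 3 nitrogen, 2 oxygen; one six-membered aromatic ring with 3 hetero atoms) in place of a group of 9 heavy atoms (3 carbon, 3 nitrogen, 3 oxygen; one six-membered aromatic ring with 3 hetero atoms), on a saturated chain carbon bound to a double-bonded chain carbon. The shared core of compound 1 stays as it is, and only the ring hung on the saturated chain carbon is exchanged.

Among the measured compounds shown here, no measured step joins compounds that differ in a single place, so the expected size of the step must be judged from compound 2, whose different ring gave a far lower number than compound 1. The step from compound 1 to compound 4 is expected to be a 2.2-fold lower number from compound 1 to compound 4 (0.35 log units; beyond the scatter), towards a stronger inhibitor. Compound 4 is estimated at 20000 nM in this assay, within a range from 5000 nM to 80000 nM.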

Compound 4, half-maximal inhibitory concentration: 41300 nM
For compound 4 the middle estimate is 2.1-fold (0.31 log units) below the measured one, within the range that was stated.
By their numbers in this assay, from the lowest: compound 2; then compounds 4 and 1 (each within the scatter of the next). At a limit, above all of these: compound 3.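

In this assay, among these compounds, the exchange on a saturated chain carbon bound to a double-bonded chain carbon gives a 1.1-fold lower number from compound 1 to compound 4 (0.04 log units; within the scatter), the first step here between compounds that differ in one place. On this shared core, then, replacing the ring with 2 hydrogen-bond donors by the ring with 1 hydrogen-bond donor leaves the two readings indistinguishable from repeat measurements of a single compound, so this particular exchange of one ring for another is not enough to separate the two compounds in this test. Nothing measured here bears on what lies behind this result.

Still open, as far as these compounds go, is whether a ring on this chain that carries an amine or a carboxylic acid would give a step beyond the scatter, and whether a longer chain between the shared core and the ring would do so. A single step at a single place also cannot show whether the same exchange would behave alike on a core with other groups in place of the two benzyloxy groups.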